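This account rests on a few compounds, and the source may have more. Where it says the series, first, only, none or still open, it means among the compounds named here.

Of the compounds shown here, three sharing one core have been measured in an ADME assay on S9 fraction from liver (Rattus norvegicus) for metabolic stability, read by LC-MS, using NADPH, with a stated time of 30 min; a lower number here means that less of the compound is left, a higher number that more of the compound is left. Compound 1 `CCCCCCCCc1ccc(OCC(=O)Cn2cnnn2)cc1` gives 22% in this assay. Compound 2 `CCCCCCCCc1ccc(OCC(=O)Cn2nnc(-c3cccc(C(=O)OC)c3)n2)cc1` gives 19%. Compound 3 `CCCCCCCCc1ccc(OCC(=O)Cn2nnc(-c3ccc(S(=O)(=O)N(C)C)cc3)n2)cc1` gives 65%, which is the highest of the three, standing a number 46 percentage points higher from compound 2 to compound 3 (beyond the scatter) and also beyond the scatter above compound 1.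

Compound 4 `CCCCCCCCc1ccc(OCC(=O)Cn2nnc(-c3ccc(C(=O)O)cc3)n2)cc1` has not yet been measured. It differs from compound 3 by carboxy in place of dimethylsulfamoyl on an aromatic carbon. For the measured compounds named here, no measured step swaps a dimethylsulfamoyl for a carboxy group, so the only related step is the one from compound 2 to compound 3, which changed a 3-(methoxycarbonyl)phenyl for a 4-(dimethylsulfamoyl)phenyl and was large. That step shows that the group on this phenyl ring can move the number a great deal in this assay, but it gives no direction for the present change.

Compound 4 is therefore expected to stay close to compound 3, with an estimated step of a number 5 percentage points lower from compound 3 to compound 4 (within the scatter) in this assay. The estimate for compound 4 is 60%, within a range from 35% to 85%.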

Compound 4, percent of the compound remaining: < 5%
Compound 4 was reported as a limit; the forecaster's own chance of this, stated with the estimate: 0%; middle value at least 55 percentage points away from the limit.
By their numbers in this assay, from the lowest: compounds 2 and 1 (each within the scatter of the next); then compound 3. At a limit, below all of these: compound 4.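

In this assay the group on this phenyl ring now shows a direction as well as a size: carboxy in place of dimethylsulfamoyl, on an aromatic carbon para to a large group, gives a number at least 60 percentage points lower from compound 3 to compound 4 (beyond the scatter). The change from the 3-(methoxycarbonyl)phenyl group to the 4-carboxyphenyl group also gives a number at least 14 percentage points lower from compound 2 to compound 4 (beyond the scatter), so the high number of compound 3 is not shared by every substituted phenyl group in this series. The value of compound 4 is a limit and not a number: the limit of < 5% in this assay, at which 1 of the 4 values shown sits.

Going by these compounds, whether an amide or a nitrile on the same aromatic carbon would stay near compound 3 or fall towards compound 4 remains open. Also open, on these data alone, is whether a 3-carboxyphenyl group would behave like the 4-carboxyphenyl group of compound 4.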